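The compounds below may be only part of what the source reports. "The series", "measured", "known", "first", "only" and "open" are said of these compounds alone.

Of the compounds shown here, three built on one shared core have been measured in a physicochemical assay for permeability, using PAMPA, at pH 7.4; on this read-out lower numbers stand for lower permeability and higher numbers for higher permeability. Compound 1 `Cc1ccccc1S(=O)(=O)NC(=O)c1ccc(Nc2nc(NC3(c4ccc(Cl)cc4)CC3)nc(OCC(F)(F)F)n2)cc1` gives 265 nm/s. Compound 2 `CC(C)(C)OC(=O)NCCS(=O)(=O)NC(=O)c1ccc(Nc2nc(NC3(c4ccc(Cl)cc4)CC3)nc(OCC(F)(F)F)n2)cc1` gives 111 nm/s, and compound 3 `CC(=O)NCCS(=O)(=O)NC(=O)c1ccc(Nc2nc(NC3(c4ccc(Cl)cc4)CC3)nc(OCC(F)(F)F)n2)cc1` gives 7 nm/s. Compound 3 therefore stands lowest of the three numbers: its nearest neighbour is compound 2, separated by a 16-fold lower number from compound 2 to compound 3 (1.20 log units; beyond the scatter), and the widest gap is a 38-fold lower number from compound 1 to compound 3 (1.58 log units; beyond the scatter). Compound 4 `COC(=O)NCCS(=O)(=O)NC(=O)c1ccc(Nc2nc(NC3(c4ccc(Cl)cc4)CC3)nc(OCC(F)(F)F)n2)cc1` has not yet been measured in this assay. It differs from compound 3 in a single place: methoxy in place of methyl on a carbonyl carbon. Read one bond further out, an acetamido group becomes a (methoxycarbonyl)amino group, so compound 4 carries the same kind of carbamate as compound 2, with methoxy where compound 2 has tert-butoxy. Among the measured compounds shown here, the one measured step that speaks to this change is a 16-fold lower number from compound 2 to compound 3 (1.20 log units; beyond the scatter), which runs in the opposite direction and is large. With methoxy rather than tert-butoxy entering, the step expected in this assay is upward but smaller than that one, estimated as a 3.6-fold higher number from compound 3 to compound 4 (0.55 log units; beyond the scatter). Compound 4 is accordingly expected to give about 25 nm/s, within a range from 10 nm/s to 70 nm/s.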

Compound 4, apparent permeability: 39 nm/s
Compound 4: the middle estimate sits 1.6-fold (0.19 log units) below what was measured; the range from low to high includes it.
By their numbers in this assay, from the lowest: compound 3; then compound 4; then compound 2; then compound 1.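

Replacing methyl with methoxy on a carbonyl carbon gives a 5.6-fold higher number from compound 3 to compound 4 (0.75 log units; beyond the scatter) in this assay and shows that this single change, turning acetamido into (methoxycarbonyl)amino, moves the read-out by more than the usual scatter. The earlier comparison of compound 2 and compound 3 changed the whole tert-butoxy group to methyl at once, whereas compound 4 divides that large step into two modest parts: the carbamate oxygen is kept while tert-butyl gives way to methyl on it, and a 2.8-fold lower number from compound 2 to compound 4 (0.45 log units; beyond the scatter) still separates this pair. Compound 4 also places the methoxy carbamate chain against the original aryl group, and a 6.8-fold lower number from compound 1 to compound 4 (0.83 log units; beyond the scatter) shows that the 2-((methoxycarbonyl)amino)ethyl chain does not match 2-methylphenyl on the sulfonyl sulfur in this read-out.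

Nothing shown here explains why any of these steps occurs. From the compounds shown here alone, it remains open whether ethyl or isopropyl on the carbamate oxygen would fall between compound 4 and compound 2, and how a 2-aminoethyl group or a carboxylic acid on a chain at the sulfonyl sulfur would read.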